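A few compounds are considered here, and "the series" means these few. Any claim that something is new, unique, unknown or untested is made for them only; others in the source may bear on it.

Compound 1 `CC(C)c1cccc(C(C)C)c1NC(=O)NCC1(c2cccc(OCc3ccccc3)c2)CCCC1` and compound 2 `CC(C)c1cccc(C(C)C)c1NC(=O)NCC1(c2cccc(N(C)C)c2)CCCC1` share one core and differ only in a single group on an aromatic carbon. In an assay on microsomes for inhibition of acyl-CoA:cholesterol acyltransferase (Oryctolagus cuniculus) (a lower number here means a stronger inhibitor, a higher number a weaker inhibitor), compound 1 gives 30 nM, and compound 2 gives 33 nM; the step of a 1.1-fold higher number from compound 1 to compound 2 (0.04 log units; within the scatter) lies within the usual scatter, so on the numbers shown compound 2 stands level with compound 1. Compound 3 `COC(=O)c1cccc(C2(CNC(=O)Nc3c(C(C)C)cccc3C(C)C)CCCC2)c1` is the next step from compound 2: methoxycarbonyl in place of dimethylamino on an aromatic carbon. Among the measured compounds shown here, the one measured step bears on it only loosely, since it exchanged a different pair of groups at the same aromatic carbon and moved the number within the scatter. For the measured compounds named here, no measured step involves methoxycarbonyl. The expectation is therefore a small step at most in this assay, if anything toward a higher number, as a 1.4-fold higher number from compound 2 to compound 3 (0.13 log units; within the scatter). Compound 3 is expected to give about 45 nM, within a range from 15 nM to 150 nM.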

Compound 3, half-maximal inhibitory concentration: 34 nM
Beside the measured number, compound 3's estimate is 1.3-fold (0.12 log units) above it; measured number inside the range.
By their numbers in this assay, from the lowest: compounds 1, 2 and 3 (each within the scatter of the next).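

In this assay, the step of a 1.0-fold higher number from compound 2 to compound 3 (0.01 log units; within the scatter) shows that methoxycarbonyl can take the place of dimethylamino on this aromatic carbon with no change beyond the scatter. The step of a 1.1-fold higher number from compound 1 to compound 3 (0.05 log units; within the scatter) reads the same way for methoxycarbonyl in place of benzyloxy, so all three compounds now stand level, and the position has held groups built from nitrogen or from oxygen, with or without a further ring and with or without a carbonyl. No measurement shown here accounts for this levelness. From the compounds shown here alone, whether a carboxylic acid, a primary amine or a longer chain on this same carbon would also stay level remains open. So does the question of whether these three groups would stay level on a different carbon of the aromatic ring.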